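The source may hold more compounds than are shown below. What is called first, only, known or untested is meant among the compounds shown, and "the series" means these compounds.

Working notes on the series. Going by the values given here, in a functional assay on aorta for antagonist activity at thromboxane A2 receptor (Rattus norvegicus) (a higher number here means weaker binding, a lower number tighter binding), compound 2 `O=C(O)CCn1cc(Cc2ccc(F)cc2)c2cc(NS(=O)(=O)c3ccc(F)cc3)ccc21` gives 0.479 nM, the lowest number of the three measured so far. Compound 3 `O=C(O)CCn1ccc2cc(NS(=O)(=O)c3ccc(Cl)cc3)ccc21` gives 2.75 nM in this assay, and compound 1 `Cc1c(Cn2ccnc2)c2cc(NS(=O)(=O)c3ccc(F)cc3)ccc2n1CCC(=O)O` gives 3800 nM, both well beyond the scatter from compound 2. Compound 4 `O=C(O)CCn1cc(Cc2ccc(F)cc2)c2cc(NS(=O)(=O)c3ccccc3)ccc21` has not yet been measured. It differs from compound 2 by hydrogen in place of fluoro on an aromatic carbon. Among the compounds with values here, no measured pair shows this same change, so the size of the step is not anchored by data; a small loss is expected, of an amount close to the scatter, with the expected step being a 1.9-fold higher number from compound 2 to compound 4 (0.27 log units; within the scatter). On that basis compound 4 is estimated to give 0.9 nM in this assay, within a range from 0.3 nM to 3 nM.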

Compound 4, dissociation constant: 0.676 nM
The estimate for compound 4 lay 1.3-fold (0.12 log units) above the measured number, within the range that was stated.
By their numbers in this assay, from the lowest: compounds 2 and 4 (each within the scatter of the next); then compound 3; then compound 1.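

In this assay, going by these compounds alone, the change from (4-fluorophenyl)sulfonyl to phenylsulfonyl gives a 1.4-fold higher number from compound 2 to compound 4 (0.15 log units; within the scatter), the first step that isolates this position. The fluoro on this aromatic carbon is therefore not required for a number this low, as hydrogen in its place stays within the scatter. No measurement at hand accounts for this result. Open, going by these compounds, is whether a larger or differently built group on this aromatic carbon, such as an amine, a methoxy or a nitrile, would keep the number at this level.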